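Swapping acetyl for pyridin-4-yl on an oxazole ketone

This account rests on a few compounds, and the source may have more. Where it says the series, first, only, none or still open, it means among the compounds named here.

Measured compounds:
Compound 1, `O=C(CCCCCCc1ccccc1)c1ccc(-c2ccco2)nn1`, > 10000 nM
Compound 2, `CC(=O)c1coc(C(=O)CCCCCCc2ccccc2)n1`, 123 nM

Of the compounds shown here, two have been tested in an assay on HEK-293T cells for inhibition of diacylglycerol lipase-alpha (Homo sapiens), read by colorimetric assay; a lower number here means a stronger inhibitor, a higher number a weaker inhibitor. Compound 1, `O=C(CCCCCCc1ccccc1)c1ccc(-c2ccco2)nn1`, reached only the limit of the assay, > 10000 nM; that value is a limit and not a number. Compound 2, `CC(=O)c1coc(C(=O)CCCCCCc2ccccc2)n1`, gives 123 nM. Among the compounds with values here, compound 2 therefore stands as the only real number in this assay; the other value shown is a limit (the limit of > 10000 nM in this assay, at which 1 of the 2 values shown sits).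

The next compound, compound 3, `O=C(CCCCCCc1ccccc1)c1nc(-c2ccncc2)co1`, has not yet been measured in this assay. It differs from compound 2 in one place: pyridin-4-yl in place of acetyl on an aromatic carbon. The pyridin-4-yl enters on an aromatic carbon of the five-membered aromatic ring with one nitrogen and one oxygen, at the position the acetyl group occupied.

Within the data shown here, no step between measured compounds is available to guide the size of this change. Compound 3 is expected to stay in the range of compound 2, with a step of a 1.6-fold higher number from compound 2 to compound 3 (0.21 log units; within the scatter) that is expected to lie close to, or modestly beyond, the usual scatter. The estimate for compound 3 in this assay is 200 nM, within 40 nM to 1500 nM.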

Compound 3, half-maximal inhibitory concentration: > 10000 nM
Compound 3: only a limit was reported (the forecaster's own chance of this, stated with the estimate: 10%); middle value at least 50-fold (1.69 log units) away from the limit.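

In this assay, the group on this aromatic carbon, next to the ring nitrogen, decides whether the shared core gives a measurable result at all: replacing acetyl with pyridin-4-yl brings an at least 81-fold higher number from compound 2 to compound 3 (1.91 log units; beyond the scatter). The value of compound 3, > 10000 nM, is a limit and not a number. This position therefore does not accept every group with a hydrogen-bond acceptor, since acetyl and pyridin-4-yl each count one, and compound 2 remains the only compound here with a real number: the limit of > 10000 nM in this assay, at which 2 of the 3 values shown sit.

The compounds shown leave open whether the result reflects the loss of the acetyl group itself or the arrival of a six-membered aromatic ring, as this single swap changes both at once. A methyl ester or a primary amide in this position would test how closely the acetyl group must be matched, while a plain phenyl ring or a pyridin-3-yl ring would show whether any aromatic ring here gives the same outcome as pyridin-4-yl.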